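This account rests on a few compounds, and the source may have more. Where it says the series, first, only, none or still open, it means among the compounds named here.

Measured so far:

Compound 1, `c1ccc(-c2nc3ccc[nH]c-3n2)cc1`: 8 mg/kg in a functional assay on the whole organism with Canis familiaris (Canis lupus familiaris) as the target; on this read-out lower numbers stand for an effect already at smaller amounts and higher numbers for an effect only at larger amounts of compound
Compound 2, `CSc1ccc(-c2nc3ccc[nH]c-3n2)cc1`: 1.9 mg/kg
Compound 3, `c1ccc(-c2nc3cc[nH]cc-3n2)cc1`: 2.5 mg/kg

Compound 1 and compound 3 are built from the same atoms joined differently; the difference between the two cores is not broken down here. Compound 2 is compound 1 with methylsulfanyl in place of hydrogen on an aromatic carbon, and this change made a 4.2-fold lower number from compound 1 to compound 2 (0.62 log units; beyond the scatter). Compound 3 sits close to compound 2, a gap that lies within the usual scatter, so no order can be read between those two; against compound 1 the gap of compound 3 lies beyond the scatter.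

Compound 4, `CSc1ccc(-c2nc3cc[nH]cc-3n2)cc1`, has not yet been measured. Going by the values given here, it is compound 3 with methylsulfanyl in place of hydrogen on an aromatic carbon, the same change at the same kind of place as the one that turned compound 1 into compound 2. The expectation for compound 4 therefore rests on a single earlier example: a step of a similar size is expected, a 3.1-fold lower number from compound 3 to compound 4 (0.49 log units; beyond the scatter), because on the other core the same change gave a 4.2-fold lower number from compound 1 to compound 2 (0.62 log units; beyond the scatter). Among the compounds with values here, with only one precedent the size of the step is uncertain, and a smaller step would not be surprising. In this assay compound 4 is expected to give about 0.8 mg/kg, with a likely range from 0.3 mg/kg to 2.5 mg/kg.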

Compound 4, dose for half-maximal effect: 4 mg/kg
Estimate against measurement, compound 4: 5.0-fold (0.70 log units) below; the measured number lies above the stated range.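

On the core of compound 3, putting methylsulfanyl in place of hydrogen gave a 1.6-fold higher number from compound 3 to compound 4 (0.20 log units; within the scatter) in this assay and so left no effect that can be told apart from the ordinary spread of repeated measurements. The clear drop in the number seen on the core of compound 1 therefore did not carry over to the second core, and the two results differ by more than chance scatter would readily explain: the same change on two cores in this assay, a 4.2-fold lower number (0.62 log units; beyond the scatter) from compound 1 to compound 2 and a 1.6-fold higher number (0.20 log units; within the scatter) from compound 3 to compound 4, 6.7-fold (0.83 log units) apart, beyond the scatter of two such steps. Going by these compounds alone, this shows that, in this series, the effect of this change depends on the core that carries it, so a step measured on one core is not a safe guide to the step on another, but with only one pair on each core it cannot show why the cores differ or which result would be more typical of a further core.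

As far as these compounds go, it remains open whether other groups at the same place on the six-membered aromatic ring of carbon only, such as methoxy, chlorine or the longer ethylsulfanyl, would also behave differently on the two cores. From the compounds shown here alone, an amine or a carboxylic acid at that place is equally open, and so is whether either core would respond to those groups at all.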